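Tetrazolyl for triazolyl on the sulfur-linked acetamide

The source may hold more compounds than are shown below. What is called first, only, known or untested is meant among the compounds shown, and "the series" means these compounds.

Compound 3 `Cn1cnnc1SCC(=O)Nc1ccc(-c2nc(-c3ccccc3)c(-c3ccccc3)n2C)cc1` gives 42.8% in a functional assay on MCF7 cells (Homo sapiens) for cytotoxicity, read by MTT assay, with a stated time of 24 h, tested at 1.6 ug/mL (on this read-out lower numbers stand for a weaker effect and higher numbers for a stronger effect at the one concentration tested), the highest of the three measured numbers. Compound 1 `Cn1c(-c2ccc(NC(=O)CCl)cc2)nc(-c2ccccc2)c1-c1ccccc1` gives 4.3% and compound 2 `Cn1c(-c2ccc(NC(=O)CSc3nc4ccccc4s3)cc2)nc(-c2ccccc2)c1-c1ccccc1` gives 2.1%; these two lie within the scatter of each other, a number 2.2 percentage points lower from compound 1 to compound 2 (within the scatter). From either of them to compound 3 the step is large: a number 38.5 percentage points higher from compound 1 to compound 3 (beyond the scatter) and a number 40.7 percentage points higher from compound 2 to compound 3 (beyond the scatter). Compound 4 `Cn1nnnc1SCC(=O)Nc1ccc(-c2nc(-c3ccccc3)c(-c3ccccc3)n2C)cc1` differs from compound 3 only at the sulfur: 1-methyl-1H-tetrazol-5-yl in place of 4-methyl-4H-1,2,4-triazol-3-yl on a sulfur. Within the data shown here, the one measured step at that sulfur, a number 40.7 percentage points higher from compound 2 to compound 3 (beyond the scatter), shows the ring there can move the number strongly, but no measured pair compares two small five-membered rings, so the direction is open. The expected step is therefore small, a number 7.8 percentage points lower from compound 3 to compound 4 (within the scatter). Compound 4 is expected at an estimated 35%, with a range from 10% to 60%.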

Compound 4, a percentage reported as activity, at one concentration (the size of the read-out at that concentration, not a potency): 34.3%
Compound 4: middle estimate off by 0.7 percentage points, on the high side, and the stated range covers the measured number.
By their numbers in this assay, from the lowest: compounds 2 and 1 (each within the scatter of the next); then compounds 4 and 3 (each within the scatter of the next).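

With two small five-membered rings on the sulfur now compared, the change from 4-methyl-4H-1,2,4-triazol-3-yl to 1-methyl-1H-tetrazol-5-yl gives a number 8.5 percentage points lower from compound 3 to compound 4 (within the scatter) and so separates the two rings by no more than the usual scatter. The high number is thus not confined to the triazolyl ring, as a number 32.2 percentage points higher from compound 2 to compound 4 (beyond the scatter) and a number 30 percentage points higher from compound 1 to compound 4 (beyond the scatter) both show for the tetrazolyl ring. No evidence at hand explains this result. From the compounds shown here alone, whether a carboxylic acid or an amine on the saturated chain carbon in place of the sulfur-linked ring would hold the number remains open.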